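From 3-amino-4-methoxyphenyl to 3-carboxy-4-methoxyphenyl: an open step

The source may hold more compounds than are shown below. What is called first, only, known or untested is meant among the compounds shown, and "the series" means these compounds.

Of the compounds shown here, three sharing one core have numbers so far. In a functional assay on HeLa cells (Homo sapiens) for antiproliferative activity, read by MTT assay, with a stated time of 48 h (on this read-out lower numbers stand for stronger inhibition and higher numbers for weaker inhibition), compound 1 (`COc1ccc(-c2cc3c(cn2)[nH]c(=O)n3-c2cc(OC)c(OC)c(OC)c2)cc1F`) gives 2210 nM, compound 2 (`COc1ccc(-c2cc3c(cn2)[nH]c(=O)n3-c2cc(OC)c(OC)c(OC)c2)cc1O`) gives 490 nM and compound 3 (`COc1ccc(-c2cc3c(cn2)[nH]c(=O)n3-c2cc(OC)c(OC)c(OC)c2)cc1N`) gives 770 nM. Compound 3 thus stands within the scatter of its hydroxy counterpart, with a 1.6-fold higher number from compound 2 to compound 3 (0.20 log units; within the scatter), and clearly apart from its fluoro counterpart, with a 2.9-fold lower number from compound 1 to compound 3 (0.46 log units; beyond the scatter).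

The next compound, compound 4 (`COc1ccc(-c2cc3c(cn2)[nH]c(=O)n3-c2cc(OC)c(OC)c(OC)c2)cc1C(=O)O`), has carboxy in place of amino on an aromatic carbon, ortho to a methoxy group and meta to a large group: carboxy in place of amino on an aromatic carbon. For the measured compounds named here, three measured steps bear on this change, all made at the same place. Replacing fluoro with hydroxy gave a 4.5-fold lower number from compound 1 to compound 2 (0.65 log units; beyond the scatter), a modest step, and the amino and hydroxy compounds differ only within the scatter. Going by the values given here, no measured compound carries carboxy, so the direction remains uncertain. A modest step towards a higher number is expected in this assay, since the largest measured step at this place is only modest. The expected move is a 2.6-fold higher number from compound 3 to compound 4 (0.41 log units; beyond the scatter). For compound 4 the estimated value is 2000 nM, with an expected range from 500 nM to 8000 nM.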

Compound 4, half-maximal inhibitory concentration: 5990 nM
Estimate against measurement, compound 4: 3.0-fold (0.48 log units) below; the range from low to high includes it.
By their numbers in this assay, from the lowest: compounds 2 and 3 (each within the scatter of the next); then compound 1; then compound 4.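

At this place, on the aromatic carbon ortho to a methoxy group, carboxy gives the highest number of the four compounds in this assay and stands apart from all the others, with a 7.8-fold higher number from compound 3 to compound 4 (0.89 log units; beyond the scatter) and with a 12-fold higher number from compound 2 to compound 4 (1.09 log units; beyond the scatter) as the largest step yet seen at this place. Even the fluoro compound, which had the highest number among the earlier three, lies clearly lower (with a 2.7-fold higher number from compound 1 to compound 4 (0.43 log units; beyond the scatter)), so the range of values at this one place is wider than the earlier compounds had shown, and the step from amino to carboxy is far from neutral. Nothing given here accounts for this step.

From the compounds shown here alone, it remains open whether the higher number belongs to the carboxy group alone or would persist with a methyl ester, a primary amide or a hydroxymethyl group at the same place. Also open, going by these compounds, is how a longer chain ending in a carboxylic acid would behave there, and whether the same order of the four compounds would hold in other cell lines.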